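The source may report more compounds than this note shows. Statements on the series, on what has been measured and on what is new or still open speak of the compounds shown alone.

Within the data shown here, in an in vitro ADME assay on microsomes from liver (Homo sapiens) for metabolic stability (a higher number here means faster removal of the compound, a lower number slower removal), the series so far holds three compounds. Compound 1 (`O=C(COCc1ccccc1)N1CCN(c2ccncc2)CC1`) is recorded as "not determined" (no result reported) and supplies no number for comparison. Compound 2 (`O=C(COCc1ccncc1)N1CCN(c2cc(Cl)ccn2)CC1`) gives 4 mL.min-1.g-1 in this measurement. Compound 3 (`O=C(COCc1ccccn1)N1CCN(c2ccc(Cl)cc2Cl)CC1`) gives 94 mL.min-1.g-1 and so holds the higher of the two numbers available, with a gap to compound 2 that lies beyond the scatter. Compounds 2 and 3 differ in more than one place, so that gap cannot be tied to any single group. Among the measured compounds shown here, no measured pair differs in one place only.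

Compound 4 (`O=C(COCc1cncs1)N1CCN(c2ccc(Cl)cc2Cl)CC1`) has yet to be measured. It carries 1,3-thiazol-5-yl in place of the pyridin-2-yl of compound 3, on a saturated chain carbon bound to an oxygen on a saturated carbon (1,3-thiazol-5-yl in place of pyridin-2-yl on a saturated chain carbon bound to an oxygen on a saturated carbon). For the measured compounds named here, with no measured single-place step to draw on, the expectation starts from compound 3 at 94 mL.min-1.g-1 and from the rest of the structure, which stays unchanged. A small downward move is expected, estimated as a 1.3-fold lower number from compound 3 to compound 4 (0.13 log units; within the scatter) and not beyond the scatter. Compound 4 is estimated at 70 mL.min-1.g-1 in this assay, with an expected range from 30 mL.min-1.g-1 to 160 mL.min-1.g-1 as the series offers so little direct evidence.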

Compound 4, intrinsic clearance in microsomes: 73 mL.min-1.g-1
For compound 4 the middle estimate is 1.0-fold (0.02 log units) below the measured one; low and high end bracket the measured number.
By their numbers in this assay, from the lowest: compound 2; then compounds 4 and 3 (each within the scatter of the next).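

In this assay, among these compounds, 1,3-thiazol-5-yl in place of pyridin-2-yl on a saturated chain carbon bound to an oxygen on a saturated carbon gives a 1.3-fold lower number from compound 3 to compound 4 (0.11 log units; within the scatter), and this is the first step that can be tied to a single place. At this position, then, a five-membered aromatic ring with 2 hetero atoms and a sulfur stands in for a six-membered aromatic ring with 1 hetero atom, and the read-out does not separate the two, so this exchange of one aromatic ring for the other, with the rest of the structure held constant, leaves the clearance reading within what repeated measurements would give. Nothing at hand bears on why the two rings read alike, and this single pair supports no rule beyond compound 3 and compound 4.

Open, on these data alone, is whether the position tolerates any change at all, as an amine, a carboxylic acid or a longer chain in place of the aromatic ring would test what a swap between two aromatic rings cannot. Also open, as far as these compounds go, is whether the same exchange reads alike on another version of the shared core, and which single place in the rest of the structure, if any, moves the number beyond the scatter.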